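The source may hold more compounds than are shown below. What is called first, only, known or untested is meant among the compounds shown, and "the series" means these compounds.

Compound 3, `CCCc1nc(-c2ccccc2)c(CNCCCN2CCN(c3ccc(F)cc3)CC2)o1`, in an assay on HEK293 cells for inhibition of Voltage-dependent T-type calcium channel subunit alpha-1G (Homo sapiens), read by patch clamp (a lower number here means a stronger inhibitor, a higher number a weaker inhibitor), gives 3210 nM. Among the three measured compounds it stands second highest: its nearest neighbour is compound 1, `CCCc1nc(-c2ccccc2)c(CNCCN2CCN(c3ccc(Cl)cc3)CC2)o1`, which in this assay gives 2820 nM, and its furthest is compound 2, `CCCc1nc(-c2ccccc2)c(CNCCN2CCN(c3ccccc3Cl)CC2)o1`, which in this assay gives 4370 nM; both of these gaps lie within the scatter. Compound 4, `CCCc1nc(-c2ccccc2)c(CNCCCN2CCN(c3cccc(F)c3)CC2)o1`, differs from compound 3 by 3-fluorophenyl in place of 4-fluorophenyl on an amine nitrogen in a ring. Among the compounds with values here, the one measured step that bears on moving a halogen to a different position of this phenyl ring is a 1.5-fold higher number from compound 1 to compound 2 (0.19 log units; within the scatter), a step within the scatter. Accordingly no change beyond the scatter is expected for compound 4 in this assay, and the expected step is a 1.1-fold higher number from compound 3 to compound 4 (0.04 log units; within the scatter). The estimate for compound 4 in this assay is 3500 nM, ranging from 1800 nM to 7000 nM.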

Compound 4, half-maximal inhibitory concentration: 3030 nM
The estimate for compound 4 lay 1.2-fold (0.06 log units) above the measured number, within the range that was stated.
By their numbers in this assay, from the lowest: compounds 1, 4, 3 and 2 (each within the scatter of the next).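

In this assay, 3-fluorophenyl in place of 4-fluorophenyl gives (a 1.1-fold lower number from compound 3 to compound 4 (0.03 log units; within the scatter)), so this fluorine can take either of these two ring positions with no change beyond the scatter. Together with the chlorine pair (a 1.5-fold higher number from compound 1 to compound 2 (0.19 log units; within the scatter)), this extends the finding from one halogen to two, though each pair covers only its own two positions. No evidence shown accounts for this result. The compounds shown leave open whether a methoxy group or a nitrile on this phenyl ring would give a step beyond the scatter, and how 2-fluorophenyl would compare.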